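This account rests on a few compounds, and the source may have more. Where it says the series, first, only, none or still open, it means among the compounds named here.

Measured compounds:
- compound 1 `Cc1ccc(C(=O)N[C@@H](C(=O)N2CCC(c3ccc(Cl)cc3)CC2)C(C)C)cc1`: 25 nM
- compound 2 `CC(C)C(NC(=O)c1ccc2ccccc2c1)C(=O)N1CCC(c2ccc(Cl)cc2)CC1`: 80 nM

In an assay on THP-1 cells for displacement of a labelled ligand from C-C chemokine receptor type 1 (Homo sapiens) (on this read-out higher numbers stand for weaker inhibition and lower numbers for stronger inhibition), compound 1 gives 25 nM, the lower of the two numbers recorded. Compound 2 gives 80 nM in this assay, a higher number that sits beyond the usual scatter, so compound 1 stands as the stronger inhibitor of the two. Going by the values given here, no single-point step between the two measured compounds is available, so nothing can be read from them about the change under consideration.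

Compound 3 `CC(C)[C@@H](NC(=O)CCCc1ccccc1)C(=O)N1CCC(c2ccc(Cl)cc2)CC1` has not yet been measured. It differs from compound 1 in one place: 3-phenylpropyl in place of 4-methylphenyl on a carbonyl carbon. Among the compounds with values here, no measured pair shows this kind of change, so the size of the step is uncertain. A modest shift towards a higher number in this assay is expected, rather than none, but a result within the scatter of compound 1 would not be surprising. Compound 3 is estimated at 60 nM, within 15 nM to 250 nM, which amounts to an expected step of a 2.4-fold higher number from compound 1 to compound 3 (0.38 log units; beyond the scatter).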

Compound 3, half-maximal inhibitory concentration: 95 nM
Compound 3: the middle estimate sits 1.6-fold (0.20 log units) below what was measured; the measured number falls inside the stated range.
By their numbers in this assay, from the lowest: compound 1; then compounds 2 and 3 (each within the scatter of the next).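

Going by these compounds alone, this is the first single-place step at the carbonyl carbon whose other neighbour is the amide-type nitrogen: in this assay, 3-phenylpropyl in place of 4-methylphenyl gives a 3.8-fold higher number from compound 1 to compound 3 (0.58 log units; beyond the scatter) and so costs a modest but real amount of inhibition. The entering group keeps the one six-membered aromatic ring of carbon only, yet that ring no longer sits directly on the carbonyl carbon, and compound 3 still retains measurable inhibition at this position. No supporting data bear on the origin of this step.

From the compounds shown here alone, whether a shorter link, as in benzyl or 2-phenylethyl, would bring the number back towards that of compound 1 remains open. Also open, going by these compounds, is how an amine or a carboxylic acid on the 3-phenylpropyl chain would shift the read-out.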